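The source may hold more compounds than are shown below. What is called first, only, known or untested is meant among the compounds shown, and "the series" means these compounds.

In a functional assay for antagonist activity at C-X-C chemokine receptor type 3 (Homo sapiens) (on this read-out higher numbers stand for weaker inhibition and lower numbers for stronger inhibition), compound 1 `CNC(=O)c1cnc(N2CCN(C3CCN(Cc4ccc(Cl)cc4)CC3)[C@@H](C)C2)c(Cl)c1` gives 32 nM. Compound 2 `CC(=O)Nc1cnc(N2CCN(C3CCN(Cc4ccc(Cl)cc4)CC3)[C@@H](C)C2)c(Cl)c1` gives 8 nM in this assay, a step of a 4.0-fold lower number from compound 1 to compound 2 (0.60 log units; beyond the scatter). Compound 3 `CCNC(=O)c1cnc(N2CCN(C3CCN(Cc4ccc(Cl)cc4)CC3)[C@@H](C)C2)c(Cl)c1` gives 2.3 nM in this assay, which is the lowest of the three numbers, with a 3.5-fold lower number from compound 2 to compound 3 (0.54 log units; beyond the scatter) and a 14-fold lower number from compound 1 to compound 3 (1.14 log units; beyond the scatter) both beyond the scatter. Compound 4 `C[C@H]1CN(c2ncc(C(=O)NCC3CCCCC3)cc2Cl)CCN1C1CCN(Cc2ccc(Cl)cc2)CC1` has not yet been measured. It differs from compound 3 by cyclohexyl in place of methyl on a saturated chain carbon bound to an amide-type nitrogen. Among the compounds with values here, the only measured step that touches this position is a 14-fold lower number from compound 1 to compound 3 (1.14 log units; beyond the scatter), where the same kind of growth on the saturated chain carbon bound to the amide-type nitrogen gave a large drop in the number. Whether a much larger group at the same place continues that movement is not shown by any pair here, and the step was already large, so only a modest further lowering, or none beyond the scatter, is expected. For compound 4 in this assay the estimate is 1.5 nM, within a range of 0.4 nM to 6 nM, which is expected to amount to a 1.5-fold lower number from compound 3 to compound 4 (0.19 log units; within the scatter).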

Compound 4, half-maximal inhibitory concentration: 2.4 nM
For compound 4 the middle estimate is 1.6-fold (0.20 log units) below the measured one, and the stated range covers the measured number.
By their numbers in this assay, from the lowest: compounds 3 and 4 (each within the scatter of the next); then compound 2; then compound 1.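

In this assay, replacing methyl with cyclohexyl on the saturated chain carbon bound to an amide-type nitrogen leaves the number unchanged within the scatter (a 1.0-fold higher number from compound 3 to compound 4 (0.02 log units; within the scatter)), so the drop seen on first adding methyl does not continue with this larger group. The lower number is kept despite the six-membered non-aromatic ring, both against the methylcarbamoyl of compound 1 (a 13-fold lower number from compound 1 to compound 4 (1.12 log units; beyond the scatter)) and against the acetamido of compound 2 (a 3.3-fold lower number from compound 2 to compound 4 (0.52 log units; beyond the scatter)). Nothing available explains why the number holds steady across this growth.

The compounds shown leave open whether a phenyl ring, a longer chain or a cyclopropyl group at this place would give a similar number. They also leave open how an amine or a carboxylic acid on the cyclohexyl ring would move it.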